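A few compounds are considered here, and "the series" means these few. Any claim that something is new, unique, unknown or untested is made for them only; others in the source may bear on it.

Measured in an ADME assay on A549 cells (Homo sapiens) for cytotoxicity, read by MTT assay, with a stated time of 48 h; on this read-out higher numbers stand for weaker inhibition of growth and lower numbers for stronger inhibition of growth:
Compound 1 `COc1ccc(/C=C\C(=O)N2N=C(c3ccncc3)OC2c2c[nH]c3ccccc23)cc1`: > 30 ug/mL
Compound 2 `O=C(/C=C\c1ccc(F)cc1)N1N=C(c2ccncc2)OC1c1c[nH]c2ccccc12`: > 30 ug/mL

Compound 2 stands at > 30 ug/mL, which is a limit and not a number. Compound 1 likewise gives only a limit. Compound 3 `O=C(/C=C/c1c(Cl)cccc1Cl)N1N=C(c2ccncc2)OC1c1c[nH]c2ccccc12` differs from compound 2 as follows: 2-(2,6-dichlorophenyl)ethenyl in place of 2-(4-fluorophenyl)ethenyl on a carbonyl carbon. Among the measured compounds shown here, the only measured step bearing on this change is a step that the two limits leave unreadable from compound 1 to compound 2, so it offers no size to carry over. The sole reference point is the limit of > 30 ug/mL in this assay, at which 2 of the 2 values shown sit. No step beyond the scatter is therefore expected in this assay, and no direction can be given. The expected outcome is a number no higher from compound 2 to compound 3 (the limit leaves the size open). Compound 3 is estimated at 30 ug/mL, within an expected range of 12 ug/mL to 60 ug/mL.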

Compound 3, concentration for 50% growth inhibition: > 30 ug/mL
Compound 3: a limit, no number; the forecaster's own chance of this, stated with the estimate: 65%; the middle value lies on the limit itself.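

In this assay compound 3 gives only a limit, as do compound 1 and compound 2, so no step among these three can be read. The compounds shown leave open how strongly any of them inhibits growth and whether the group on the carbonyl carbon changes that.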